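The source may hold more compounds than are shown below. What is called first, only, known or untested is meant among the compounds shown, and "the series" means these compounds.

Working notes on a uracil-derived series measured in a functional assay on MCF7 cells (Homo sapiens) for antiproliferative activity, read by MTT assay, with a stated time of 72 h; a higher number here means a weaker inhibitor, a lower number a stronger inhibitor.

Compound 1 `O=c1[nH]c(=O)n(CCC(CO)CO)cc1-c1ccco1` carries the simplest substitution pattern of the three. In this assay compound 1 returns only a limit, < 10 nM, not a number. That limit is the one at which (the limit of < 10 nM in this assay, at which 1 of the 2 values shown sits), so compound 1 offers no fixed point for comparison.

Among the measured compounds shown here, compound 2 `CC(=O)OCC(CCn1cc(C#Cc2cc(F)cc(F)c2)c(=O)n(C(=O)c2ccccc2)c1=O)COC(C)=O` is the one compound with a numeric result: in this assay compound 2 gives 28900 nM. For the measured compounds named here, since the other value shown is a limit, compound 2 stands as the only measured number in the set, and no step between two measured compounds can be drawn from it.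

Compound 3 `CCCCCCCCC#Cc1cn(CCC(COC(C)=O)COC(C)=O)c(=O)n(C(=O)c2ccccc2)c1=O` is not yet measured. It differs from compound 2 in one place: octyl in place of 3,5-difluorophenyl on a triple-bonded carbon. Going by the values given here, no measured pair shows what such a change does in this assay, so no direction can be taken from the data. The step from a 1.3-fold lower number from compound 2 to compound 3 (0.12 log units; within the scatter) is expected to stay within the usual scatter. On that basis compound 3 is estimated at 22000 nM, with a range from 6000 nM to 80000 nM.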

Compound 3, half-maximal inhibitory concentration: 28900 nM
Estimate against measurement, compound 3: 1.3-fold (0.12 log units) below; measured number inside the range.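

Among the compounds shown here, the series now has its first readable step in this assay: octyl in place of 3,5-difluorophenyl on a triple-bonded carbon gives no change at the digits printed from compound 2 to compound 3 (within the scatter), the only pair here that differs in one place. At this position, an open chain and a fluorinated aromatic ring with the same number of heavy atoms therefore read alike, which shows for this pair that the six-membered aromatic ring is not needed to hold the number where it stands. Nothing at hand gives a measured property that bears on this result.

One pair cannot show whether any group on this triple-bonded carbon would move the number, and an amine, a carboxylic acid or a chain longer than octyl in the same place remains untested in the compounds shown. Steps to compound 1 cannot be read, and with several differences from compound 2 and compound 3 it leaves open which part of the structure separates it from them.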